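Compound 3 and its stereo partner, compound 4

The source may hold more compounds than are shown below. What is called first, only, known or untested is meant among the compounds shown, and "the series" means these compounds.

Compound 1 `OCCC[C@@H]1O[C@H](COCc2ccccc2)[C@@H](OCc2ccccc2)[C@H](OCc2ccccc2)[C@H]1O`: > 50000 nM, a limit
Compound 2 `CC(=O)O[C@@H]1[C@@H](OCc2ccccc2)[C@H](OC(C)=O)[C@@H](COCc2ccccc2)O[C@H]1Cc1ccccc1`: 6100 nM
Compound 3 `c1ccc(COC[C@H]2O[C@H]3C[C@H]3[C@@H](OCc3ccccc3)[C@@H]2OCc2ccccc2)cc1`: > 50000 nM, a limit

All three compounds were tested in a functional assay on HOS cells (Homo sapiens) for antiproliferative activity, read by sulforhodamine B assay; a lower number here means a stronger inhibitor of growth, a higher number a weaker inhibitor of growth. Compound 3 gives > 50000 nM, which is a limit of the assay and not a number. Compound 1 gives > 50000 nM, which is also a limit. Compound 3 therefore stands at the limit of > 50000 nM in this assay, at which 2 of the 3 values shown sit. Only compound 2 gives a true number, 6100 nM.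

Compound 4 `c1ccc(COC[C@H]2O[C@@H]3C[C@@H]3[C@@H](OCc3ccccc3)[C@@H]2OCc2ccccc2)cc1` is closely related to compound 3: the two compounds have the same atoms and bonds and differ only in configuration as drawn: 2 of 5 stereo elements differ; a stereocentre at a saturated ring carbon is drawn S in compound 3 and R in compound 4; a stereocentre at a saturated ring carbon is drawn R in compound 3 and S in compound 4. The atoms stay the same, and only their arrangement in space changes. Going by the values given here, no measured pair shows what such a change does in this assay, so this forecast is uncertain. The expected step of a number no higher from compound 3 to compound 4 (the limit leaves the size open) stays within the usual scatter, with no direction favoured. The range still reaches down towards compound 2, at 6100 nM, as a real number cannot be ruled out. Compound 4 is estimated at 50000 nM, with an expected range of 12000 nM to 100000 nM.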

Compound 4, concentration for 50% growth inhibition: > 50000 nM
Compound 4: a limit, no number; the forecaster's own chance of this, stated with the estimate: 75%; the middle value lies on the limit itself.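

In this assay, going by these compounds alone, compound 3 and compound 4 each give only a limit and not a number, so no step between the two can be read. The compounds shown leave open whether this change in configuration at two ring carbons alters growth inhibition at all.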